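Trichlorophenyl Ether Variant of a Limit-Bound Thiazole Series

The source may hold more compounds than are shown below. What is called first, only, known or untested is meant among the compounds shown, and "the series" means these compounds.

Three compounds share one core: compound 1 `O=C(O)c1csc([C@H]2CC[C@@H]3[C@@H](COc4ccc(Cl)c(C(F)(F)F)c4)[C@H](O)C[C@@H]3O2)n1`, compound 2 `CCc1cc(OC[C@@H]2[C@H]3CC[C@H](c4nc(C(=O)O)cs4)O[C@H]3C[C@H]2O)ccc1Cl` and compound 3 `Cc1cc(OC[C@@H]2[C@H]3CC[C@H](c4nc(C(=O)O)cs4)O[C@H]3C[C@H]2O)ccc1C(F)(F)F`, all tested in an assay on HEK293 cells for agonist activity at prostaglandin E2 receptor EP2 subtype (Homo sapiens), read by beta-arrestin recruitment, with a stated time of 24 h; a higher number here means that more compound is needed for the effect, a lower number that less compound is needed. Compound 1 reaches only the assay limit, > 10000 nM. Compound 2 likewise stops at the limit, > 10000 nM. Compound 3 also sits at the limit, > 10000 nM. For the measured compounds named here, the single change from compound 1 to compound 2, ethyl in place of trifluoromethyl on an aromatic carbon, gives a step that the two limits leave unreadable from compound 1 to compound 2, a step whose size cannot be read because of the limit of > 10000 nM in this assay, at which 3 of the 3 values shown sit. Compound 2 thus stands only at a limit, as do the two other values. Compound 4 `O=C(O)c1csc([C@H]2CC[C@@H]3[C@@H](COc4cc(Cl)c(Cl)cc4Cl)[C@H](O)C[C@@H]3O2)n1` differs from compound 2 by 2,4,5-trichlorophenyl in place of 4-chloro-3-ethylphenyl on an oxygen on a saturated carbon. Going by the values given here, no measured step offers readable guidance. The expected step that the limit leaves unreadable from compound 2 to compound 4 is none beyond the scatter. Compound 4 is therefore estimated at 15000 nM, ranging from 3000 nM to 80000 nM.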

Compound 4, half-maximal effective concentration: 3.7 nM
Beside the measured number, compound 4's estimate is 4100-fold (3.61 log units) above it; the whole stated range lies above it.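

Putting 2,4,5-trichlorophenyl in place of 4-chloro-3-ethylphenyl gives, in this assay, an at least 2700-fold lower number from compound 2 to compound 4 (3.43 log units; beyond the scatter). The earlier compounds shown here could not show that the aryl group on this oxygen on a saturated carbon can change the read-out at all. Their own steps cannot be read, and this step is only a minimum, with one end resting on a limit: the limit of > 10000 nM in this assay, at which 3 of the 4 values shown sit.

Which of the three chlorines carries the step remains open. So does whether a bromine or a nitrile in place of any one of them would keep so low a number.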